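Pyridinium salts: from cyclopropylmethyl to cyclobutylmethyl

The source may report more compounds than this note shows. Statements on the series, on what has been measured and on what is new or still open speak of the compounds shown alone.

Compound 2 `COc1cc2cc(C(=O)CCc3cc[n+](CC4CC4)cc3)sc2cc1OC` is, in a physicochemical assay for solubility (a lower number here means a less soluble compound, a higher number a more soluble compound), the more soluble of the two compounds measured: compound 2 gives 15000 ug/mL, while compound 1 `COc1cc2cc(C(=O)CCc3cc[n+](C)cc3)sc2cc1OC` gives 3000 ug/mL. Within the data shown here, the one step that has been measured, a 5.0-fold higher number from compound 1 to compound 2 (0.70 log units; beyond the scatter), shows how far one change at this position has moved the read-out.

Compound 3 `COc1cc2cc(C(=O)CCc3cc[n+](CC4CCC4)cc3)sc2cc1OC` carries a related change at the same position: cyclobutyl in place of cyclopropyl on a saturated chain carbon bound to an aromatic nitrogen. Among the measured compounds shown here, no measured step matches this change exactly. The step from compound 1 to compound 2 added a ring where none was, whereas here one ring is exchanged for a ring with one more carbon, a smaller alteration. For compound 3 an estimate of 10000 ug/mL is therefore made, with a range of 4000 ug/mL to 25000 ug/mL, meaning an expected step of a 1.5-fold lower number from compound 2 to compound 3 (0.18 log units; within the scatter) that stays within the scatter.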

Compound 3, solubility: 6000 ug/mL
Estimate against measurement, compound 3: 1.7-fold (0.22 log units) above; the measured number falls inside the stated range.
By their numbers in this assay, from the lowest: compounds 1 and 3 (each within the scatter of the next); then compound 2.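

In this assay, the size of the ring on the saturated chain carbon bound to the aromatic nitrogen turns out to matter: there is a 2.5-fold lower number from compound 2 to compound 3 (0.40 log units; beyond the scatter), so exchanging cyclopropyl for cyclobutyl is not a neutral swap. The earlier gain does not carry over to the larger ring: there is a 2.0-fold higher number from compound 1 to compound 3 (0.30 log units; within the scatter), so this pair cannot be told apart on this read-out. Nothing available here explains why one added ring carbon changes the number in this way.

The compounds shown leave open what cyclopentylmethyl, an open chain such as isobutyl, or a chain ending in an amine would give at this place. Among these compounds, with only two ring sizes, they also cannot establish a general rule linking ring size to this read-out.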